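A Nitrile Added Where Only a Limit Was Found

The source may hold more compounds than are shown below. What is called first, only, known or untested is meant among the compounds shown, and "the series" means these compounds.

Compound 1 `COc1ccc(COc2cc([N+](=O)[O-])ccc2N(C)S(C)(=O)=O)cc1` and compound 2 `O=C(Nc1ccc([N+](=O)[O-])cc1OCc1ccccc1)c1ccccc1` were both tested in an assay on SK-BR-3 cells for inhibition of Aromatase (Homo sapiens); a lower number here means a stronger inhibitor, a higher number a weaker inhibitor. Compound 1 gives 470 nM in this assay. For compound 2, this assay reports only a limit, > 25000 nM, so the actual number is not known. This is the limit of > 25000 nM in this assay, at which 1 of the 2 values shown sits, and it places compound 2 at the weak end of what has been shown so far.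

Compound 3 `N#Cc1ccc(C(=O)Nc2ccc([N+](=O)[O-])cc2OCc2ccccc2)cc1` has not yet been measured. It differs from compound 2 in one place: cyano in place of hydrogen on an aromatic carbon. No measured pair shows this same change, so the direction and size of the step cannot be read from the data, and no cause can be given for whatever it turns out to be. The expectation is that compound 3 comes out somewhat stronger, with the estimated step of an at least 2.0-fold lower number from compound 2 to compound 3 (0.31 log units; beyond the scatter) only modestly beyond the scatter, and with a real chance that this assay again reports a limit rather than a number. Compound 3 is therefore estimated at 12000 nM, with a range from 2000 nM to 40000 nM.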

Compound 3, half-maximal inhibitory concentration: > 25000 nM
Compound 3 ended at the assay's limit (the forecaster's own chance of this, stated with the estimate: 55%); middle value at least 2.0-fold (0.31 log units) from the limit.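

In this assay compound 3 gives > 25000 nM, which is a limit and not a number. Compound 2 also stands at a limit, so no step between compound 2 and compound 3 can be read: the limit of > 25000 nM in this assay, at which 2 of the 3 values shown sit.

The compounds shown leave open whether cyano in place of hydrogen on an aromatic carbon changes inhibition at all.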